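The compounds below may be only part of what the source reports. "The series", "measured", "known", "first", "only" and "open" are said of these compounds alone.

Values in a functional assay on MDA-MB-231 cells (Homo sapiens) for inhibition, read by MTT assay, with a stated time of 48 h (on this read-out lower numbers stand for stronger inhibition of growth and higher numbers for weaker inhibition of growth), so far:
- Compound 1 `NS(=O)(=O)c1ccc(NC(=S)Nc2ccc3ncnc(Nc4cccc(Br)c4)c3c2)cc1` gives > 30000 nM as a limit of the assay.
- Compound 2 `FC(F)(F)c1cccc(NC(=S)Nc2ccc3ncnc(Nc4cccc(Br)c4)c3c2)c1` gives 1400 nM as a number.

For the measured compounds named here, compound 2 holds the only numeric value so far, the other result being a limit. Going by the values given here, the sole measured step, an at least 21-fold lower number from compound 1 to compound 2 (1.33 log units; beyond the scatter), shows that the group on this amide-type nitrogen can move the read-out widely. Compound 3 `S=C(Nc1cc(Cl)cc(Cl)c1)Nc1ccc2ncnc(Nc3cccc(Br)c3)c2c1` has 3,5-dichlorophenyl in place of 3-(trifluoromethyl)phenyl on an amide-type nitrogen. Among the compounds with values here, the 4-sulfamoylphenyl group of that large step plays no part here, so no step of that size is expected. The expected step, a 1.2-fold lower number from compound 2 to compound 3 (0.07 log units; within the scatter), lies within the scatter. Compound 3 is estimated at 1200 nM with an expected range from 400 nM to 4000 nM in this assay.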

Compound 3, concentration for 50% growth inhibition: 3000 nM
Beside the measured number, compound 3's estimate is 2.5-fold (0.40 log units) below it; the range from low to high includes it.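

Replacing 3-(trifluoromethyl)phenyl with 3,5-dichlorophenyl on this amide-type nitrogen is not neutral in this assay, with a 2.1-fold higher number from compound 2 to compound 3 (0.33 log units; beyond the scatter) as the result, so the two lipid-free aryl choices are not interchangeable here. The comparison with 4-sulfamoylphenyl gives an at least 10-fold lower number from compound 1 to compound 3 (1.00 log units; beyond the scatter) and shows that a second aryl group also stands far from it. That step is only a bound, as compound 1 gives a limit: the limit of > 30000 nM in this assay, at which 1 of the 3 values shown sits. Still open, from the compounds shown here alone, is how an unsubstituted phenyl, or a phenyl carrying an amine or a carboxylic acid, would read at this position.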